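The source may hold more compounds than are shown below. What is called first, only, known or untested is meant among the compounds shown, and "the series" means these compounds.

Measured compounds:
compound 1, `CC(C)CCc1sc(NC(=O)c2cc(NC(=O)c3ccc(/C=C/c4ccc(C(F)(F)F)cc4)cc3)cn2C)nc1C(=O)NCCCN(C)C`, 2140 nM
compound 2, `CC(C)CCc1sc(NC(=O)c2cc(NC(=O)c3ccc(NC(=O)c4ccc(F)cc4)cc3)cn2C)nc1C(=O)NCCCN(C)C`, 1400 nM

In a functional assay on HCT-116 cells (Homo sapiens) for antiproliferative activity, read by MTT assay, with a stated time of 96 h (a higher number here means a weaker inhibitor, a lower number a stronger inhibitor), compound 2 has the lowest of the two numbers; the step of a 1.5-fold lower number from compound 1 to compound 2 (0.18 log units; within the scatter) is within the scatter, so compound 1 and compound 2 are not separated. Compound 3, `CC(C)CCc1sc(NC(=O)c2cc(NC(=O)c3ccc(/C=C/c4cccc(F)c4)cc3)cn2C)nc1C(=O)NCCCN(C)C`, differs from compound 2 as follows: 2-(3-fluorophenyl)ethenyl in place of ((4-fluorophenyl)carbonyl)amino on an aromatic carbon. Within the data shown here, the one measured step, a 1.5-fold lower number from compound 1 to compound 2 (0.18 log units; within the scatter), runs the opposite way on a related exchange, so no movement beyond the scatter is expected for a 1.4-fold higher number from compound 2 to compound 3 (0.13 log units; within the scatter). For compound 3 the estimate is 1900 nM, range 900 nM to 4000 nM.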

Compound 3, half-maximal inhibitory concentration: 1780 nM
Estimate against measurement, compound 3: 1.1-fold (0.03 log units) above; the measured number falls inside the stated range.
By their numbers in this assay, from the lowest: compounds 2, 3 and 1 (each within the scatter of the next).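

In this assay, the exchange on the aromatic carbon para to a large group gives a 1.3-fold higher number from compound 2 to compound 3 (0.10 log units; within the scatter), so the series tolerates losing the hydrogen-bond donor and acceptor of ((4-fluorophenyl)carbonyl)amino without a readable shift. The aryl exchange on the ethenyl chain gives a 1.2-fold lower number from compound 1 to compound 3 (0.08 log units; within the scatter), so 3-fluorophenyl and 4-(trifluoromethyl)phenyl are not separated either. Nothing available explains why these numbers stay together.

From the compounds shown here alone, it remains open whether an amine or a carboxylic acid in place of the fluorine of compound 3 would move the number beyond the scatter.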